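A few compounds are considered here, and "the series" means these few. Any claim that something is new, unique, unknown or untested is made for them only; others in the source may bear on it.

Working notes on the series, with all numbers from a functional assay on KB 3-1 cells (Homo sapiens) for cytotoxicity, read by MTT assay, with a stated time of 72 h; a higher number here means a weaker inhibitor, a lower number a stronger inhibitor. Going by the values given here, compound 1 `O=C1Nc2ccccc2/C1=N/NC(=S)Nc1ccccc1` gives 3530 nM and stands as the lower of the two numbers so far. Compound 2 `O=C1Nc2ccccc2/C1=N/NC(=S)NC1CCCCC1` gives 9140 nM and is the nearest neighbour.

The next structure is compound 3 `COc1ccccc1NC(=S)N/N=C1\C(=O)Nc2ccccc21`, which differs from compound 1 in one place: methoxy in place of hydrogen on an aromatic carbon. This is methoxy in place of hydrogen on an aromatic carbon of a six-membered aromatic ring of carbon only, ortho to a large group.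

Among the compounds with values here, one measured step bears on this, and only loosely: a 2.6-fold higher number from compound 1 to compound 2 (0.41 log units; beyond the scatter), for cyclohexyl in place of phenyl on an amide-type nitrogen. That step is modest but beyond the scatter. Within the data shown here, compound 3 keeps the phenyl, and no measured step covers a substituent on that ring, so the data set no direction. A step no larger than that modest one is expected in this assay, quite possibly none beyond the scatter.

The estimate amounts to an expected 1.0-fold lower number from compound 1 to compound 3 (0.00 log units; within the scatter). For compound 3 the estimated value is 3500 nM, with an expected range from 1400 nM to 8500 nM.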

Compound 3, half-maximal inhibitory concentration: 4960 nM
For compound 3 the middle estimate is 1.4-fold (0.15 log units) below the measured one; low and high end bracket the measured number.
By their numbers in this assay, from the lowest: compounds 1, 3 and 2 (each within the scatter of the next, the first and the last beyond it).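

In this assay, methoxy in place of hydrogen on an aromatic carbon, ortho to a large group, gives a 1.4-fold higher number from compound 1 to compound 3 (0.15 log units; within the scatter), so the two compounds cannot be told apart on this read-out. Going by these compounds alone, this is the first measured substitution on the phenyl ring itself, and at this place a group of 2 heavy atoms with 1 hydrogen-bond acceptor produces no step beyond the scatter, unlike the earlier replacement of the whole ring in a 2.6-fold higher number from compound 1 to compound 2 (0.41 log units; beyond the scatter). No measured evidence bears on the reason for this result.

The compounds shown leave open whether the same place on the ring would accept other groups in the same way, such as a chlorine atom, a hydroxyl, an amine, a carboxylic acid or a longer alkoxy chain. They also leave open whether methoxy elsewhere on the phenyl ring, or a second methoxy, would stay within the scatter of compound 1 or produce a clear step in either direction.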